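A few compounds are considered here, and "the series" means these few. Any claim that something is new, unique, unknown or untested is made for them only; others in the source may bear on it.

Series notes. Within the data shown here, compound 1 `CCn1ncc2c(F)cc(-c3ccc(C(CC)(CC)c4nnc(C)[nH]4)c(=O)[nH]3)cc21` is one of two compounds measured in an ADME assay on microsomes from liver (Rattus norvegicus) for metabolic stability; a higher number here means that the compound lasts longer, a lower number that the compound disappears faster. In this assay compound 1 gives > 3 h, which is a limit of the assay and not a number (the limit of > 3 h in this assay, at which 1 of the 2 values shown sits). Compound 2 `CC(C)C(c1ccc(-c2ccc3cccc(F)c3c2)[nH]c1=O)N1CCCCC1=O` gives 0.102 h, the only number shown for this assay. Compound 3 `CC(C)C(Cc1noc(=O)[nH]1)c1ccc(-c2ccc3cccc(F)c3c2)[nH]c1=O` is not yet measured in this assay. It differs from compound 2 by a group of 7 heavy atoms (3 carbon, 2 nitrogen, 2 oxygen; one five-membered aromatic ring with 3 hetero atoms) in place of a group of 7 heavy atoms (5 carbon, 1 nitrogen, 1 oxygen; one six-membered non-aromatic ring with 1 hetero atom), on a saturated chain carbon bound to an aromatic carbon and a saturated chain carbon. Among the measured compounds shown here, no measured step covers such a change, so the direction is open, and a shift beyond the usual scatter is not expected. Compound 3 is estimated at 0.15 h, between 0.05 h and 0.5 h. The expected step is a 1.5-fold higher number from compound 2 to compound 3 (0.17 log units; within the scatter).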

Compound 3, half-life: > 3 h
Compound 3 ended at the assay's limit (the forecaster's own chance of this, stated with the estimate: 5%); at least 20-fold (1.30 log units) between middle value and limit.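

In this assay, among these compounds, the one step read at this saturated chain carbon is an at least 29-fold higher number from compound 2 to compound 3 (1.46 log units; beyond the scatter), so the group held here can move the half-life by a large amount while the rest of the structure stays the same. The value of compound 3 is a limit of the assay and not a number: the limit of > 3 h in this assay, at which 2 of the 3 values shown sit.

The compounds shown do not tell how a carboxylic acid or a primary amine on this carbon would read. They also leave open whether a smaller lactam or an open-chain amide would keep the short half-life of compound 2.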